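A few compounds are considered here, and "the series" means these few. Any claim that something is new, unique, unknown or untested is made for them only; others in the source may bear on it.

In a functional assay on L1210 cells (Mus musculus) for inhibition; a lower number here means a stronger inhibitor, a higher number a weaker inhibitor:

Compound 1 `C=C1[C@H](n2cnc3c(Cl)nc(N)nc32)O[C@H](CO)[C@H]1O`: 10000 nM
Compound 2 `C=C1[C@H](n2cnc3c(N)nc(N)nc32)O[C@H](CO)[C@H]1O`: 8200 nM
Compound 3 `C=C1[C@H](n2cnc3c(N(C)C)nc(N)nc32)O[C@H](CO)[C@H]1O`: 454000 nM

Compound 2 shares the low end of these numbers, with a 1.2-fold lower number from compound 1 to compound 2 (0.09 log units; within the scatter), against a 55-fold higher number from compound 2 to compound 3 (1.74 log units; beyond the scatter). Compound 4 `C=C1[C@H](n2cnc3c(N)ncnc32)O[C@H](CO)[C@H]1O` differs from it by hydrogen in place of amino on an aromatic carbon, between two ring nitrogen atoms. Within the data shown here, all three measured compounds keep that amino group, so no measured step tests its loss. The steps at hand exchange a different group, and they range from a 1.2-fold lower number from compound 1 to compound 2 (0.09 log units; within the scatter) to the large 45-fold higher number from compound 1 to compound 3 (1.66 log units; beyond the scatter). They set no direction, so no shift beyond the scatter is expected in this assay, though uncertainty stays wide. For compound 4 the estimated value is 10000 nM, with an expected range of 2000 nM to 50000 nM. This estimate means an expected 1.2-fold higher number from compound 2 to compound 4 (0.09 log units; within the scatter).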

Compound 4, half-maximal inhibitory concentration: 65000 nM
Compound 4: middle estimate off by 6.5-fold (0.81 log units), on the low side; the whole stated range lies below it.
By their numbers in this assay, from the lowest: compounds 2 and 1 (each within the scatter of the next); then compound 4; then compound 3.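

In this assay, hydrogen in place of amino on the aromatic carbon between two ring nitrogen atoms gives a 7.9-fold higher number from compound 2 to compound 4 (0.90 log units; beyond the scatter), so the amino group that all earlier compounds kept does matter to the read-out. Among these compounds, this is the first step at this position, and it lies beyond the scatter, though it is modest in size. No available information bears on why the number rises.

The compounds shown leave open whether a methylamino group or a hydroxyl at this position would keep the number of compound 2. They also leave open whether losing this amino group would cost as much with chloro in place of the amino group that compound 4 retains.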